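The source may hold more compounds than are shown below. What is called first, only, known or untested is meant among the compounds shown, and "the series" means these compounds.

Three compounds have been measured in an ADME assay on MDCKII-LE cells (Canis lupus familiaris) for permeability, read by transwell migration, in the apical to basolateral direction; on this read-out higher numbers stand for higher permeability and lower numbers for lower permeability:

Compound 1 `NC(=O)[C@@H](CCC(F)(F)F)N(CC1COC1)S(=O)(=O)c1ccc(Cl)cc1` gives 25.4 10^-6 cm/s.
Compound 2 `CC1(C)C[C@H](CN([C@H](CCC(F)(F)F)C(N)=O)S(=O)(=O)c2ccc(Cl)cc2)O1` gives 18.1 10^-6 cm/s.
Compound 3 `NC(=O)[C@@H](CCC(F)(F)F)N(C[C@H]1CCOC1)S(=O)(=O)c1ccc(Cl)cc1` gives 21.7 10^-6 cm/s.

Compound 1 has the highest of the three numbers, but its separation from the other two is small: the step of a 1.2-fold lower number from compound 1 to compound 3 (0.07 log units; within the scatter) and the step of a 1.4-fold lower number from compound 1 to compound 2 (0.15 log units; within the scatter) both sit inside the usual scatter of this kind of measurement, so the three compounds cannot be ranked with confidence. Compound 4 `NC(=O)[C@@H](CCC(F)(F)F)N(C[C@H]1CCCO1)S(=O)(=O)c1ccc(Cl)cc1` is the next compound on this path and differs from compound 1 in one place: oxolan-2-yl in place of oxetan-3-yl on a saturated chain carbon bound to a sulfonamide nitrogen. Going by the values given here, the steps that bear on this change are those in which the same ring position was varied, the step of a 1.2-fold lower number from compound 1 to compound 3 (0.07 log units; within the scatter) to an oxolan-3-yl and the step of a 1.4-fold lower number from compound 1 to compound 2 (0.15 log units; within the scatter) to a 4,4-dimethyloxetan-2-yl, together with the step of a 1.2-fold higher number from compound 2 to compound 3 (0.08 log units; within the scatter) between those two; none of them reached beyond the scatter. A similar outcome is therefore expected here, with no step beyond the scatter in this assay. For compound 4 the expected value is 22 10^-6 cm/s, within a range from 14 10^-6 cm/s to 34 10^-6 cm/s, which corresponds to an estimated step of a 1.2-fold lower number from compound 1 to compound 4 (0.06 log units; within the scatter).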

Compound 4, apparent permeability: 19.1 10^-6 cm/s
For compound 4 the middle estimate is 1.2-fold (0.06 log units) above the measured one, and the stated range covers the measured number.
By their numbers in this assay, from the lowest: compounds 2, 4, 3 and 1 (each within the scatter of the next).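

With oxolan-2-yl on this saturated chain carbon bound to a sulfonamide nitrogen, one more ring swap stays inside the scatter of this assay: the change from the four-membered oxetan-3-yl gives (a 1.3-fold lower number from compound 1 to compound 4 (0.12 log units; within the scatter)), and the change from 4,4-dimethyloxetan-2-yl gives (a 1.1-fold higher number from compound 2 to compound 4 (0.02 log units; within the scatter)). New here is a pair in which the same five-membered ring is attached through a different ring carbon, oxolan-3-yl against oxolan-2-yl, and this change also stays inside the scatter (a 1.1-fold lower number from compound 3 to compound 4 (0.06 log units; within the scatter)). Across these four compounds, neither ring size nor point of attachment moves the number beyond the scatter, and no supporting data say why.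

All four compounds carry an oxygen-containing ring in this place. Still open, on these data alone, is whether a ring without oxygen such as cyclopentyl, an open methoxyethyl chain, an amine or a carboxylic acid would leave the number equally close.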